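The source may hold more compounds than are shown below. What is called first, only, known or untested is meant among the compounds shown, and "the series" means these compounds.

In an ADME assay on A549 cells (Homo sapiens) for cytotoxicity, read by resazurin assay, with a stated time of 48 h (a higher number here means that more compound is tolerated, a lower number that less compound is tolerated), three compounds that share one core and differ in a single group on a saturated chain carbon bound to a nitrogen on an aromatic ring have been measured. Compound 1 `CN(C)c1ccc(CNc2ccc(NC(=O)c3cc(Cl)ccc3O)c(Cl)c2)cc1` gives 24500 nM, compound 2 `O=C(Nc1ccc(NCc2cc(F)cc(Cl)c2)cc1Cl)c1cc(Cl)ccc1O` gives 11100 nM, and compound 3 `O=C(Nc1ccc(NCc2ccncc2)cc1Cl)c1cc(Cl)ccc1O` gives 65300 nM, the highest of the three numbers. Compound 4 `O=C(Nc1ccc(NCc2ccc(O)nc2)cc1Cl)c1cc(Cl)ccc1O` changes the same place, with 6-hydroxypyridin-3-yl in place of pyridin-4-yl on a saturated chain carbon bound to a nitrogen on an aromatic ring. Going by the values given here, no measured step makes this exact exchange. The three steps at this place are all modest: a 2.2-fold lower number from compound 1 to compound 2 (0.34 log units; beyond the scatter), a 2.7-fold higher number from compound 1 to compound 3 (0.43 log units; beyond the scatter) and a 5.9-fold higher number from compound 2 to compound 3 (0.77 log units; beyond the scatter). Among the compounds with values here, compound 4 keeps one six-membered aromatic ring with 1 hetero atom, as compound 3 does, so a change no larger than those steps seems likely, and possibly none beyond the scatter. The expected change is slightly downward, and the estimated step is a 1.2-fold lower number from compound 3 to compound 4 (0.07 log units; within the scatter). For compound 4 the estimated value is 55000 nM, with an expected range from 24000 nM to 125000 nM.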

Compound 4, half-maximal cytotoxic concentration: 98500 nM
Beside the measured number, compound 4's estimate is 1.8-fold (0.25 log units) below it, and the stated range covers the measured number.
By their numbers in this assay, from the lowest: compound 2; then compound 1; then compounds 3 and 4 (each within the scatter of the next).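

In this assay the exchange at this place gives a 1.5-fold higher number from compound 3 to compound 4 (0.18 log units; within the scatter) and so adds a hydroxy group and a hydrogen-bond donor to the six-membered aromatic ring with 1 hetero atom without moving the number beyond the scatter. Compound 4 also stands clear of both phenyl compounds, with an 8.9-fold higher number from compound 2 to compound 4 (0.95 log units; beyond the scatter) and a 4.0-fold higher number from compound 1 to compound 4 (0.60 log units; beyond the scatter) as its steps, so among the four compounds shown both pyridine-bearing compounds give higher numbers than both phenyl-bearing ones, and none goes against this. Nothing given here accounts for these differences.

The compounds shown do not separate the effect of the hydroxy group from that of the change from pyridin-4-yl to a pyridin-3-yl attachment, which plain pyridin-3-yl would address. Going by these compounds, how an amine or a carboxylic acid in place of that hydroxy group would read also remains open.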